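From compound 3 to compound 4: working notes

This account rests on a few compounds, and the source may have more. Where it says the series, first, only, none or still open, it means among the compounds named here.

Measured in a functional assay with Oryctolagus cuniculus as the target; a lower number here means a stronger inhibitor, a higher number a weaker inhibitor:
- compound 1 `COc1ccc(-c2nc(CN)sc2-c2ccc(OC)cc2)cc1`: > 100 nM (a limit)
- compound 2 `COc1ccc(-c2nc(CNC(=O)N3CCOCC3)sc2-c2ccc(OC)cc2)cc1`: 660 nM
- compound 3 `COc1ccc(-c2nc(CNC(=O)NC(C)C)sc2-c2ccc(OC)cc2)cc1`: 42 nM

Of the two actual numbers, compound 3 has the lower. The entry for compound 1 is only a limit.

Compound 4 `CCN(CC)C(=O)c1nc(-c2ccc(OC)cc2)c(-c2ccc(OC)cc2)s1` carries diethylcarbamoyl in place of ((isopropylcarbamoyl)amino)methyl on an aromatic carbon. Among the compounds with values here, no measured step covers this exchange directly. The closest guides are a 16-fold lower number from compound 2 to compound 3 (1.20 log units; beyond the scatter) and an at least 2.3-fold lower number from compound 1 to compound 3 (0.37 log units; beyond the scatter), which show that changes in this side chain can move this assay considerably. Starting from the low number of compound 3, a moderate to large rise is expected, with wide uncertainty. The expected step is a 4.8-fold higher number from compound 3 to compound 4 (0.68 log units; beyond the scatter). For compound 4 the estimated value is 200 nM, with an expected range of 35 nM to 1200 nM.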

Compound 4, half-maximal inhibitory concentration: < 10 nM
Compound 4: no number, only a limit; the forecaster's own chance of this, stated with the estimate: 15%; at least 20-fold (1.30 log units) between middle value and limit.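

In this assay, diethylcarbamoyl on the aromatic carbon beats all three side chains that it replaces: an at least 4.2-fold lower number from compound 3 to compound 4 (0.62 log units; beyond the scatter), an at least 66-fold lower number from compound 2 to compound 4 (1.81 log units; beyond the scatter) and an at least 10-fold lower number from compound 1 to compound 4 (1.00 log units; beyond the scatter). A low number at this position therefore does not require the hydrogen-bond donors that leave with ((isopropylcarbamoyl)amino)methyl. The entry for compound 4 is a limit and not a number: the limit of < 10 nM in this assay, at which 1 of the 4 values shown sits.

Still open is how far the low number depends on the two ethyl groups, as the compounds shown do not tell how dimethylcarbamoyl or a piperidine amide would read here. They also leave open how a carboxylic acid would read at this position.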